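Shifting the Thiophene Attachment Point in Compound 1

The source may report more compounds than this note shows. Statements on the series, on what has been measured and on what is new or still open speak of the compounds shown alone.

Among the compounds with values here, compound 1 `COc1ncnc2c1c(-c1ccsc1)cn2[C@@H]1O[C@H](CO)[C@@H](O)[C@H]1O` is the one member of this small set with a numerical result: in a functional assay on HeLa S3 cells (Homo sapiens) for antiproliferative activity, read by XTT assay, with a stated time of 72 h (a lower number here means a stronger inhibitor, a higher number a weaker inhibitor), compound 1 gives 3350 nM. Its companion compound 2 `CN(C)c1ncnc2c1c(-c1ccsc1)cn2[C@@H]1O[C@H](CO)[C@@H](O)[C@H]1O` carries dimethylamino in place of methoxy on an aromatic carbon. In this assay compound 2 reaches only a limit of the assay, > 15000 nM. The step of an at least 4.4-fold higher number from compound 1 to compound 2 (0.65 log units; beyond the scatter) is therefore known only as a bound, set by the limit of > 15000 nM in this assay, at which 1 of the 2 values shown sits. Compound 3 `COc1ncnc2c1c(-c1cccs1)cn2[C@@H]1O[C@H](CO)[C@@H](O)[C@H]1O` keeps the methoxy group of compound 1 and differs from it elsewhere: thiophen-2-yl in place of thiophen-3-yl on an aromatic carbon. Within the data shown here, no measured pair in this set changes the thiophene attachment, and the single measured step concerns the methoxy position, so it offers no direct guide to the move from thiophen-3-yl to thiophen-2-yl. With nothing beyond the scatter to anchor a direction, the expected step of a 1.1-fold lower number from compound 1 to compound 3 (0.05 log units; within the scatter) is one of no clear change. On that basis compound 3 is estimated to give 3000 nM in this assay, within a range of 800 nM to 12000 nM.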

Compound 3, half-maximal inhibitory concentration: 1760 nM
Beside the measured number, compound 3's estimate is 1.7-fold (0.23 log units) above it; low and high end bracket the measured number.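

In this assay, shifting the thiophene attachment gives a 1.9-fold lower number from compound 1 to compound 3 (0.28 log units; within the scatter), so thiophen-2-yl and thiophen-3-yl, which have the same atoms and the same counts of donors and acceptors, cannot be told apart at this aromatic carbon of the five-membered ring. Within the data shown here, this is the first reading at this position, as the only earlier step concerned the methoxy group, and it shows that, with methoxy kept in place, either attachment of the thiophene leaves the read-out within the usual scatter. Nothing measured in the compounds shown speaks to the reason the two thiophene attachments read alike.

The compounds shown leave open whether this position accepts anything other than a thiophene, such as a phenyl ring, a furan or an aminomethyl group, as both groups seen at this place are thiophenes. They also leave open how thiophen-2-yl behaves with dimethylamino in place of methoxy on the shared core.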